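This account rests on a few compounds, and the source may have more. Where it says the series, first, only, none or still open, it means among the compounds named here.

Measured compounds:
- compound 1 `Cc1cc(Cl)c(-c2ncc[nH]2)cc1NC(=O)c1ccc(OCc2ccccn2)cc1`: > 3
- compound 2 `Cc1cc(Cl)c(-c2cn(C)cn2)cc1NC(=O)c1ccc(OCc2ccccn2)cc1`: 3.1
- compound 3 `Cc1cc(Cl)c(-c2cn(C)c(C)n2)cc1NC(=O)c1ccc(OCc2ccccn2)cc1`: 3.3

The three compounds share one core and differ only in the five-membered ring attached to it. In a physicochemical assay for lipophilicity (on this read-out lower numbers stand for lower lipophilicity and higher numbers for higher lipophilicity), compound 1 reaches only a limit of the assay and not a number, as the limit of > 3 in this assay, at which 1 of the 3 values shown sits, states. For that reason the step that the limit leaves unreadable from compound 1 to compound 2 and the step that the limit leaves unreadable from compound 1 to compound 3 cannot be read in size. Between the two compounds with full numbers, the step of a number 0.20 log units higher from compound 2 to compound 3 (within the scatter) is small and lies within the usual scatter, so compound 2 and compound 3 cannot be told apart on this read-out.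

Compound 4 `Cc1cc(C)c(-c2ncc[nH]2)cc1NC(=O)c1ccc(OCc2ccccn2)cc1` keeps the ring of compound 1 and changes the core itself: methyl in place of chloro on an aromatic carbon. Going by the values given here, none of the measured steps makes this exchange; the only step read in full swaps methyl for hydrogen on the five-membered ring, and that is not the same change. Compound 1 itself gives only a limit, so the starting point is known only as a range. The value of compound 4 is therefore expected to sit near the limit, and this estimate carries wide uncertainty. For compound 4 the estimated value in this assay is 3, with a range from 2.5 to 3.5. The expected step is a number no higher from compound 1 to compound 4 (the limit leaves the size open), read from an uncertain start.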

Compound 4, distribution coefficient: 3.1
Beside the measured number, compound 4's estimate is 0.10 log units below it; the measured number falls inside the stated range.
By their numbers in this assay, from the lowest: compounds 2, 4 and 3 (each within the scatter of the next).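

No new step can be read from compound 1 to compound 4 in this assay, because compound 1 gives only a limit and not a number: the limit of > 3 in this assay, at which 1 of the 4 values shown sits. The compounds shown leave open how large the change is when methyl takes the place of chloro on the shared core.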